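The compounds below may be only part of what the source reports. "The series", "measured", "known", "first", "only" and "open" are said of these compounds alone.

Working notes on the series in a functional assay on MOLT-4 cells (Homo sapiens) for cytotoxicity, read by sulforhodamine B assay, with a stated time of 48 h; on this read-out lower numbers stand for higher toxicity in this test and higher numbers for lower toxicity in this test.

Within the data shown here, compound 1, `ClCc1ccccc1Cn1cnc2c(Cl)nc(Cl)nc21`, is the only member with a numerical read-out so far: in this assay compound 1 gives 3540 nM. Compound 2, `ClCc1cccc(Cn2cnc3c(Cl)nc(Cl)nc32)c1`, carries the same atoms joined differently; the difference between the two cores is not broken down here. In this assay compound 2 reaches only a limit of the assay, > 100000 nM. Compound 3, `Nc1nc(Cl)c2ncn(Cc3ccccc3CCl)c2n1`, is reached from compound 1 by a single change, (amino in place of chloro on an aromatic carbon), and in this assay compound 3 likewise gives only a limit, > 100000 nM. The step of an at least 28-fold higher number from compound 1 to compound 3 (1.45 log units; beyond the scatter) is therefore counted from the limit, and the true step may be larger. Two of the three values now sit at the same limit, (the limit of > 100000 nM in this assay, at which 2 of the 3 values shown sit).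

Compound 4, `Nc1nc(Cl)c2ncn(Cc3cccc(CCl)c3)c2n1`, has not yet been measured. Among the measured compounds shown here, it stands to compound 2 as compound 3 stands to compound 1: the change amino in place of chloro on an aromatic carbon is the same change as the one made from compound 1 to compound 3, at the same place. Since that change lowered toxicity in this assay from compound 1 to compound 3 by at least the step shown, and since compound 2 already sits at the limit, compound 4 is expected to remain at or beyond the limit; the expected step is a number no higher from compound 2 to compound 4 (the limit leaves the size open). The estimate for compound 4 in this assay is 100000 nM, within 50000 nM to 300000 nM, with a limit value rather than a number the most likely outcome.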

Compound 4, concentration lethal to 50% of the cells: > 100000 nM
Compound 4 was reported as a limit; the forecaster's own chance of this, stated with the estimate: 90%; the middle value lies on the limit itself.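

Compound 2 and compound 4 both stand at a limit in this assay, so no step can be read between them: the limit of > 100000 nM in this assay, at which 3 of the 4 values shown sit.

The compounds shown leave open whether amino in place of chloro on an aromatic carbon changes toxicity in this test at all when starting from compound 2, and how far past the limit compound 2, compound 3 and compound 4 truly lie.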